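Swapping the aryl group: what to expect for compound 4

This account rests on a few compounds, and the source may have more. Where it says the series, first, only, none or still open, it means among the compounds named here.

Compound 1, `CC(C)(C)n1ncc(OCc2nnc(-c3ccccc3Cl)o2)c(Cl)c1=O`, gives 61.2 ug/mL in a functional assay on the whole organism for inhibition, with Mythimna separata as the target, with a stated time of 5 days; on this read-out higher numbers stand for an effect only at larger amounts of compound and lower numbers for an effect already at smaller amounts.
Compound 2, `Cc1nnc(COc2cnn(C(C)(C)C)c(=O)c2Cl)o1`, gives only a limit of the assay, > 300 ug/mL, in this assay.
Compound 3, `CCc1ccc(-c2nnc(COc3cnn(C(C)(C)C)c(=O)c3Cl)o2)cc1`, gives 14.5 ug/mL in this assay.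

Among the numbers shown, compound 3 stands lowest, with compound 1 nearest at a higher number; the value of compound 2 is a limit of > 300 ug/mL in this assay, at which 1 of the 3 values shown sits, and not a number. Compound 4, `CC(C)(C)n1ncc(OCc2nnc(-c3cc(F)c(Cl)cc3Cl)o2)c(Cl)c1=O`, is not yet measured. It differs from compound 3 in one place: 2,4-dichloro-5-fluorophenyl in place of 4-ethylphenyl on an aromatic carbon. Among the compounds with values here, three measured steps bear on this change. There was a 4.2-fold lower number from compound 1 to compound 3 (0.63 log units; beyond the scatter), there was an at least 20-fold lower number from compound 2 to compound 3 (1.31 log units; beyond the scatter), and there was an at least 4.9-fold higher number from compound 1 to compound 2 (0.69 log units; beyond the scatter). Compound 4 thus carries a chlorine-bearing phenyl group, as compound 1 does, in place of the 4-ethylphenyl of compound 3, so a number closer to that of compound 1 is expected. For compound 4 the expected value in this assay is 45 ug/mL, with a range from 12 ug/mL to 160 ug/mL. This estimate corresponds to an expected 3.1-fold higher number from compound 3 to compound 4 (0.49 log units; beyond the scatter).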

Compound 4, half-maximal effective concentration: 23.1 ug/mL
Beside the measured number, compound 4's estimate is 1.9-fold (0.29 log units) above it; low and high end bracket the measured number.
By their numbers in this assay, from the lowest: compounds 3 and 4 (each within the scatter of the next); then compound 1. At a limit, above all of these: compound 2.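

With 2,4-dichloro-5-fluorophenyl in place of 4-ethylphenyl, this assay shows a 1.6-fold higher number from compound 3 to compound 4 (0.20 log units; within the scatter), so at this position a phenyl group carrying three halogens and one carrying an ethyl group cannot be told apart. Chlorine on the phenyl group does not by itself set the number, since 2,4-dichloro-5-fluorophenyl in place of 2-chlorophenyl gives a 2.6-fold lower number from compound 1 to compound 4 (0.42 log units; beyond the scatter). The wide gap to methyl also holds for this new phenyl group, with an at least 12-fold lower number from compound 2 to compound 4 (1.11 log units; beyond the scatter), where the starting value is a limit of the assay and not a number: the limit of > 300 ug/mL in this assay, at which 1 of the 4 values shown sits.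

Which of the two chlorines and the fluorine accounts for the step from the 2-chlorophenyl group stays open. Also open, as far as these compounds go, is how this position would respond to an amine, a carboxylic acid or a longer chain on the phenyl group.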